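Swapping vinyl for methylimidazolyl on the side chain of compound 2

The source may hold more compounds than are shown below. What is called first, only, known or untested is meant among the compounds shown, and "the series" means these compounds.

Compound 1 `CC(C)(C)c1ccc2ccccc2c1O` and compound 2 `C=CCc1ccc2ccccc2c1O` share one core. In an assay on RBL-1 cells with Polyunsaturated fatty acid 5-lipoxygenase (Rattus norvegicus) as the target (on this read-out lower numbers stand for stronger inhibition and higher numbers for weaker inhibition), compound 1 gives 180 nM, while compound 2 gives 56 nM, the lowest of the two numbers, reached by a 3.2-fold lower number from compound 1 to compound 2 (0.51 log units; beyond the scatter). Compound 3 `Cn1ccnc1Cc1ccc2ccccc2c1O` differs from compound 2 by 1-methyl-1H-imidazol-2-yl in place of vinyl on a saturated chain carbon bound to an aromatic carbon. Among the compounds with values here, the one measured step concerns a different exchange at the same place, so it shows only that substituents there move the number modestly. The step of a 1.6-fold higher number from compound 2 to compound 3 (0.21 log units; within the scatter) is therefore expected to be small, with its direction uncertain. For compound 3 in this assay the estimate is 90 nM, between 20 nM and 400 nM.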

Compound 3, half-maximal inhibitory concentration: 3500 nM
For compound 3 the middle estimate is 39-fold (1.59 log units) below the measured one, outside the stated range (above it).
By their numbers in this assay, from the lowest: compound 2; then compound 1; then compound 3.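

In this assay, 1-methyl-1H-imidazol-2-yl in place of vinyl on a saturated chain carbon bound to an aromatic carbon weakens inhibition sharply, giving a 63-fold higher number from compound 2 to compound 3 (1.80 log units; beyond the scatter). That step is far larger than the modest earlier one, a 3.2-fold lower number from compound 1 to compound 2 (0.51 log units; beyond the scatter), so a change at this place can cost much more than that step showed. Nothing available here accounts for the loss.

As far as these compounds go, it remains open whether the loss follows the imidazole ring itself or its methyl group. Equally open, from the compounds shown here alone, is how a phenyl ring or a dimethylamino group would fare on the same chain carbon.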